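This account rests on a few compounds, and the source may have more. Where it says the series, first, only, none or still open, it means among the compounds named here.

For the measured compounds named here, in an assay on isolated protein for inhibition of Amine oxidase [flavin-containing] A (Homo sapiens), read by fluorescence and Amplex Red, with a stated time of 30 min (a lower number here means a stronger inhibitor, a higher number a weaker inhibitor), compound 1 `CCNc1nnc(SCC(=O)N(Cc2cccc([N+](=O)[O-])c2)c2ccc(F)cc2)s1` gives 336 nM, and compound 2 `CC(C)CNc1nnc(SCC(=O)N(Cc2cccc([N+](=O)[O-])c2)c2ccc(F)cc2)s1` gives 1790 nM, the higher of the two numbers so far, with compound 1 as its nearest neighbour. Going by the values given here, the only measured step, a 5.3-fold higher number from compound 1 to compound 2 (0.73 log units; beyond the scatter), is the one that bears on the next change. Compound 3 `CC(C)Nc1nnc(SCC(=O)N(Cc2cccc([N+](=O)[O-])c2)c2ccc(F)cc2)s1` differs from compound 2 by isopropyl in place of isobutyl on a nitrogen on an aromatic ring, so the chain entering is smaller than the one leaving, though it remains branched. A partial reversal of that step is therefore expected, a 2.2-fold lower number from compound 2 to compound 3 (0.35 log units; beyond the scatter). Compound 3 is estimated at 800 nM, range 300 nM to 2500 nM.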

Compound 3, half-maximal inhibitory concentration: 1070 nM
Compound 3: middle estimate off by 1.3-fold (0.13 log units), on the low side; the range from low to high includes it.
By their numbers in this assay, from the lowest: compound 1; then compounds 3 and 2 (each within the scatter of the next).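

In this assay the change at this nitrogen gives a 1.7-fold lower number from compound 2 to compound 3 (0.22 log units; within the scatter), so isopropyl and isobutyl cannot be told apart here. A methyl on the saturated chain carbon bound to this nitrogen is enough on its own to give a step beyond the scatter, a 3.2-fold higher number from compound 1 to compound 3 (0.50 log units; beyond the scatter), so compound 1 remains separated from compound 3 as well as from compound 2. No measurement available here explains this step.

Still open, from the compounds shown here alone, is how a straight propyl chain, a cyclopropyl ring or a plain amine would read at this nitrogen. Whether chain length or branching governs the numbers also remains unsettled.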